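Compound 3 to Compound 4: a Larger Group on the Ring Amine

The compounds below may be only part of what the source reports. "The series", "measured", "known", "first", "only" and "open" are said of these compounds alone.

Of the compounds shown here, three sharing one core have been measured in a functional assay on MCF7 cells (Homo sapiens) for cytotoxicity, read by MTT assay, with a stated time of 24 h, tested at 32 ug/mL; a lower number here means a weaker effect, a higher number a stronger effect of the compound at the concentration tested. Compound 1 `Cn1c(-c2ccc(NC(=O)CCl)cc2)nc(-c2ccccc2)c1-c1ccccc1` gives 42.8%, compound 2 `Cc1nnc(SCC(=O)Nc2ccc(-c3nc(-c4ccccc4)c(-c4ccccc4)n3C)cc2)s1` gives 83.4%, and compound 3 `CCN1CCN(CC(=O)Nc2ccc(-c3nc(-c4ccccc4)c(-c4ccccc4)n3C)cc2)CC1` gives 38.6%. Compound 3 thus holds the lowest of the three numbers: a number 4.2 percentage points lower from compound 1 to compound 3 (within the scatter), so compounds 1 and 3 cannot be told apart, whereas a number 44.8 percentage points lower from compound 2 to compound 3 (beyond the scatter), a large gap. Compound 4 `Cc1ccc(CN2CCN(CC(=O)Nc3ccc(-c4nc(-c5ccccc5)c(-c5ccccc5)n4C)cc3)CC2)cc1` differs from compound 3 only at the ring amine: 4-methylphenyl in place of methyl on a saturated chain carbon bound to an amine nitrogen in a ring. Within the data shown here, none of the measured steps touches this place; each of them, including a number 40.6 percentage points higher from compound 1 to compound 2 (beyond the scatter), changes the group on the saturated chain carbon bound to the carbonyl carbon, so the data offer no direct guide to the size or direction of the new step. The expectation is therefore that compound 4 stays close to compound 3. A step of a number 5.4 percentage points higher from compound 3 to compound 4 (within the scatter) is expected, not clearly beyond the scatter. Compound 4 is estimated at 44%, with a range from 25% to 68%.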

Compound 4, a percentage reported as activity, at one concentration (the size of the read-out at that concentration, not a potency): 31.5%
Estimate against measurement, compound 4: 12.5 percentage points above; measured number inside the range.
By their numbers in this assay, from the lowest: compounds 4, 3 and 1 (each within the scatter of the next, the first and the last beyond it); then compound 2.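

Swapping methyl for 4-methylphenyl on a saturated chain carbon bound to an amine nitrogen in a ring enlarges the group from one heavy atom to seven and adds an aromatic ring, yet in this assay this gives a number 7.1 percentage points lower from compound 3 to compound 4 (within the scatter). So at this new place, a much larger all-carbon group with no hydrogen-bond donors or acceptors produces no step beyond the scatter, unlike the exchange on the saturated chain carbon bound to the carbonyl carbon, a number 40.6 percentage points higher from compound 1 to compound 2 (beyond the scatter). Nothing available accounts for this outcome.

On these data alone, it remains open whether a pyridin-4-yl or a 4-carboxyphenyl group at this place would move the read-out beyond the scatter. A single concentration also leaves open how the potencies of compound 3 and compound 4 compare.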